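The source may hold more compounds than are shown below. What is called first, only, known or untested is meant among the compounds shown, and "the series" means these compounds.

Measured so far in a functional assay on MDA-MB-435 cells (Homo sapiens) for cytotoxicity, read by sulforhodamine B assay, with a stated time of 48 h; a higher number here means that more compound is tolerated, a lower number that less compound is tolerated:
Compound 1 `ClCc1ccccc1Cn1cnc2c(Cl)nc(Cl)nc21` gives 6450 nM in this assay.
Compound 2 `Nc1nc(Cl)c2ncn(Cc3ccc(CCl)cc3)c2n1` gives only a limit of > 100000 nM in this assay.
Compound 3 `ClCc1ccccc1Cn1cnc2c(Cl)ncnc21` gives 36300 nM in this assay.

Compound 3 holds the highest of the two numbers; the nearest, compound 1, sits lower, the step of a 5.6-fold higher number from compound 1 to compound 3 (0.75 log units; beyond the scatter) coming from hydrogen in place of chloro on an aromatic carbon. Compound 4 `Nc1nc(Cl)c2ncn(Cc3ccccc3CCl)c2n1` differs from compound 3 by amino in place of hydrogen on an aromatic carbon. Going by the values given here, no measured step makes this same change, so the only pointer is compound 2, which also carries an amino group and reaches only the limit, though it differs from compound 4 in another place as well. The step of a 2.8-fold higher number from compound 3 to compound 4 (0.44 log units; beyond the scatter) is therefore expected to go upward, possibly to the limit. Compound 4 is estimated at 100000 nM, expected between 30000 nM and 300000 nM.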

Compound 4, concentration lethal to 50% of the cells: > 100000 nM
Compound 4: no number, only a limit; the forecaster's own chance of this, stated with the estimate: 50%; the middle value sits exactly at the limit.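

Amino in place of hydrogen at this place, between two ring nitrogen atoms, gives an at least 2.7-fold higher number from compound 3 to compound 4 (0.44 log units; beyond the scatter), and amino in place of chloro gives an at least 15-fold higher number from compound 1 to compound 4 (1.19 log units; beyond the scatter). Across compound 1, compound 3 and compound 4, more compound is tolerated going from chloro to hydrogen to amino at this one place. Compound 4 gives a limit rather than a number, so both steps are minimum sizes: the limit of > 100000 nM in this assay, at which 2 of the 4 values shown sit.

As far as these compounds go, the true size of the amino step stays open. So does whether a methoxy or dimethylamino group here would behave like amino or like chloro.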